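This account rests on a few compounds, and the source may have more. Where it says the series, first, only, none or still open, it means among the compounds named here.

Three compounds of this series have a measured value in a physicochemical assay for lipophilicity, read by HPLC, at pH 7.4; on this read-out lower numbers stand for lower lipophilicity and higher numbers for higher lipophilicity. Compound 1, `C[C@@H](Oc1cc2onc(CCC(=O)O)c2cc1Cl)c1ccc(F)cn1`, gives 2.47 in this assay. Compound 2, `O=C(O)CCn1c(=O)oc2cc(OCc3ccccc3)c(Cl)cc21`, gives 2.71 in this assay. Compound 3, `Cc1ccnc([C@@H](C)Oc2cc3oc(=O)n(CCC(=O)O)c3cc2Cl)c1`, gives 2.15 in this assay. Among these three, compound 2 has the highest number. The gap between compound 2 and compound 1 lies within the usual scatter, so nothing can be said about their order. The gap between compound 2 and compound 3 lies beyond the scatter, so compound 2 does stand above compound 3 in this assay. Among the compounds with values here, none of these three compounds differ from one another in a single place, so no single-change step is available among them.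

Compound 4, `O=C(O)CCn1c(=O)oc2cc(OCc3ccccn3)c(Cl)cc21`, has not yet been measured in this assay. Its structure differs from compound 2 in one place: pyridin-2-yl in place of phenyl on a saturated chain carbon bound to an oxygen on an aromatic ring. On this assay, the step from compound 2 to compound 4 is expected to be a lowering, clearly beyond the scatter, of about a number 1.11 log units lower from compound 2 to compound 4 (beyond the scatter). Compound 4 is therefore expected to give roughly 1.6 in this assay, most plausibly falling between 1.1 and 2.1.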

Compound 4, distribution coefficient: 1.32
For compound 4 the middle estimate is 0.28 log units above the measured one; the range from low to high includes it.
By their numbers in this assay, from the lowest: compound 4; then compound 3; then compounds 1 and 2 (each within the scatter of the next).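

In this assay, the series now has its first single-change step: on a saturated chain carbon bound to an oxygen on an aromatic ring, pyridin-2-yl in place of phenyl gives a number 1.39 log units lower from compound 2 to compound 4 (beyond the scatter) and counts as large. The two groups have the same number of heavy atoms, and the change amounts to one ring carbon exchanged for one nitrogen, which brings in one hydrogen-bond acceptor; this position therefore responds strongly in this read-out to a replacement that leaves the count of heavy atoms unchanged. No measurement given here accounts for why the step is so large.

The compounds shown leave open whether pyridin-3-yl, pyridin-4-yl or pyrimidin-2-yl at the same place would lower the number as far, so the result cannot yet be tied to the presence of a ring nitrogen as such or to where that nitrogen sits. Within the data shown here, they also leave open whether the same exchange of phenyl for pyridin-2-yl would give a step of similar size on another core, since this single pair is the only such comparison available.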